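Sugar hydroxy added to the longer-chain nucleoside analogue

This account rests on a few compounds, and the source may have more. Where it says the series, first, only, none or still open, it means among the compounds named here.

Of the compounds shown here, three built on a shared core have been tested in a functional assay on HEL cells (Homo sapiens) for cytotoxicity; on this read-out lower numbers stand for higher toxicity in this test and higher numbers for lower toxicity in this test. Compound 1 `CCCCC#Cc1cc2cn([C@H]3C[C@H](O)[C@@H](CO)O3)c(=O)nc2o1` is the starting point. In this assay compound 1 gives only a limit, > 150000 nM, not a number. Compound 2 `CCCCC#Cc1cc2cn([C@@H]3O[C@H](CO)[C@@H](O)[C@@H]3O)c(=O)nc2o1` differs from compound 1 by hydroxy in place of hydrogen on a saturated ring carbon. In this assay compound 2 likewise gives a limit, > 144000 nM. Compound 3 `CCCCCCC#Cc1cc2cn([C@H]3C[C@H](O)[C@@H](CO)O3)c(=O)nc2o1` differs from compound 1 in the chain: ethyl in place of hydrogen on a saturated chain carbon, four bonds along the chain from a triple-bonded carbon. In this assay compound 3 also gives a limit, >= 97000 nM. With every reading stopping at a limit, the two steps between measured compounds cannot be sized: a step that the two limits leave unreadable from compound 1 to compound 2, and a step that the two limits leave unreadable from compound 1 to compound 3.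

Compound 4 `CCCCCCC#Cc1cc2cn([C@@H]3O[C@H](CO)[C@@H](O)[C@@H]3O)c(=O)nc2o1` has not yet been measured; it joins the sugar of compound 2 to the chain of compound 3. From compound 3 it differs by hydroxy in place of hydrogen on a saturated ring carbon, the same change that leads from compound 1 to compound 2, at the same place. Beside the earlier step that the two limits leave unreadable from compound 1 to compound 2, the step expected here is a step that the limit leaves unreadable from compound 3 to compound 4. This expectation rests on compound 3, whose reading is a limit (the limit of >= 97000 nM in this assay, at which 1 of the 3 values shown sits). Compound 4 is therefore expected near 150000 nM, most likely again reported only as a limit.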

Compound 4, minimum cytotoxic concentration: 133000 nM
Beside the measured number, compound 4's estimate is 1.1-fold (0.05 log units) above it; low and high end bracket the measured number.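

In this assay, within the data shown here, compound 4 gives a true number, 133000 nM, and the only step that can be read with it is an at least 1.0-fold lower number from compound 2 to compound 4 (0.03 log units; that floor lies within the scatter); this step is the chain change, ethyl in place of hydrogen, and not the hydroxy change. All the other steps cannot be read, including both hydroxy steps, one on the core of compound 1 and one on the core of compound 3, so the data show neither that the hydroxy change carries over from one core to the other nor that it fails to. Compound 3 gives only a limit, not a number: the limit of >= 97000 nM in this assay, at which 1 of the 4 values shown sits.

Still open, from the compounds shown here alone, is how the reading would move with a longer chain than that of compound 3, or with an amine at the end of the chain. Also open, going by these compounds, is what size the hydroxy change would take if compound 1 and compound 3 had numbers in this assay rather than limits.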